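The source may hold more compounds than are shown below. What is called first, only, known or untested is meant among the compounds shown, and "the series" means these compounds.

Compound 3 `O=C(NCCNc1nccc(-c2c(-c3cccc(F)c3)nc3sccn23)n1)c1ccccc1` is the compound with the highest number among the three measured: in a functional assay on SK-MEL-28 cells (Homo sapiens) for cytotoxicity, read by MTT assay (on this read-out lower numbers stand for stronger inhibition and higher numbers for weaker inhibition), compound 3 gives 17000 nM. Compound 1 `O=S(=O)(NCCCNc1nccc(-c2c(-c3cccc(F)c3)nc3sccn23)n1)c1cccc(F)c1` gives 8550 nM, and compound 2 `O=C(NCCNc1nccc(-c2c(-c3cccc(F)c3)nc3sccn23)n1)c1ccc(C(F)(F)F)cc1` gives 9260 nM. Both of these lie within the scatter of compound 3, as the steps of a 2.0-fold higher number from compound 1 to compound 3 (0.30 log units; within the scatter) and a 1.8-fold higher number from compound 2 to compound 3 (0.26 log units; within the scatter) show, so the three cannot be ordered.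

Compound 4 `Cc1ccc(C(=O)NCCNc2nccc(-c3c(-c4cccc(F)c4)nc4sccn34)n2)cc1` differs from compound 3 by one change: methyl in place of hydrogen on an aromatic carbon. The step that bears on it is a 1.8-fold higher number from compound 2 to compound 3 (0.26 log units; within the scatter), in which a group was likewise exchanged for hydrogen on an aromatic carbon of the benzamido ring and the number moved only within the scatter. For the measured compounds named here, nothing among the measured compounds points to a step beyond the scatter for adding a methyl here. Compound 4 is therefore expected to show at most a small change, a 1.3-fold lower number from compound 3 to compound 4 (0.12 log units; within the scatter), in this assay. The estimate for compound 4 is 13000 nM, within a range from 5000 nM to 32000 nM.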

Compound 4, half-maximal inhibitory concentration: 18800 nM
Compound 4: middle estimate off by 1.4-fold (0.16 log units), on the low side; measured number inside the range.
By their numbers in this assay, from the lowest: compounds 1, 2, 3 and 4 (each within the scatter of the next, the first and the last beyond it).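

In this assay, a methyl on this aromatic carbon, para to a large group, is a change that stays within the scatter, a 1.1-fold higher number from compound 3 to compound 4 (0.04 log units; within the scatter), so this small carbon substituent leaves the number in place. For the compounds shown here, the new compound also gives the first steps beyond the scatter in this small set, both modest: methyl against trifluoromethyl on the same carbon, a 2.0-fold higher number from compound 2 to compound 4 (0.31 log units; beyond the scatter), and the ((4-methylphenyl)carbonyl)amino end against the (((3-fluorophenyl)sulfonyl)amino)methyl end, a 2.2-fold higher number from compound 1 to compound 4 (0.34 log units; beyond the scatter). No evidence at hand accounts for either step.

As far as these compounds go, whether an amine or a carboxylic acid on this carbon would move the number further stays open. So does the effect of a longer chain on the benzamido series.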